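Swapping the Carboxy-Hydroxy Ring Group for an Amine Chain

This account rests on a few compounds, and the source may have more. Where it says the series, first, only, none or still open, it means among the compounds named here.

Of the compounds shown here, three sharing one core have so far been tested in an ADME assay on HEK293 cells (Homo sapiens) for cytotoxicity, read by CCK-8 assay, with a stated time of 48 h; on this read-out higher numbers stand for weaker inhibition and lower numbers for stronger inhibition. Compound 1 `COc1ccc(/C=C\c2cc(OC)c(OC)c(OC)c2)cc1OCc1ccc(CN2CC(C(=O)O)C2)cc1` gives > 50000 nM, which is a limit of the assay rather than a number. Compound 2 `COc1ccc(/C=C\c2cc(OC)c(OC)c(OC)c2)cc1OCc1ccc(CN2C[C@H](O)C[C@@H]2C(=O)O)cc1` gives > 50000 nM, again only a limit. Compound 3 `COc1ccc(/C=C\c2cc(OC)c(OC)c(OC)c2)cc1OCc1ccc(CNCCNC(C)=O)cc1` likewise gives > 50000 nM, a limit. Because (the limit of > 50000 nM in this assay, at which 3 of the 3 values shown sit), compound 2 cannot be placed above or below its neighbours, and the steps a step that the two limits leave unreadable from compound 1 to compound 2 and a step that the two limits leave unreadable from compound 2 to compound 3 carry no readable size. Compound 4 `COc1ccc(/C=C\c2cc(OC)c(OC)c(OC)c2)cc1OCc1ccc(CNCCN(C)C)cc1` differs from compound 2 by (2-(dimethylamino)ethyl)amino in place of 2-carboxy-4-hydroxypyrrolidin-1-yl on a saturated chain carbon bound to an aromatic carbon. With no readable step to lean on, no shift beyond the scatter is expected, so compound 4 is expected to sit at 50000 nM, within 20000 nM to 50000 nM, meaning an expected step of a number no higher from compound 2 to compound 4 (the limit leaves the size open).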

Compound 4, half-maximal inhibitory concentration: 39000 nM
Beside the measured number, compound 4's estimate is 1.3-fold (0.11 log units) above it; low and high end bracket the measured number.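

In this assay, going by these compounds alone, compound 4, with (2-(dimethylamino)ethyl)amino on a saturated chain carbon bound to an aromatic carbon, is the first compound to give a real number, and replacing 2-carboxy-4-hydroxypyrrolidin-1-yl gives an at least 1.2-fold lower number from compound 2 to compound 4 (0.10 log units; that floor lies within the scatter). Dimethylamino in place of acetamido gives an at least 1.2-fold lower number from compound 3 to compound 4 (0.10 log units; that floor lies within the scatter), and replacing 3-carboxyazetidin-1-yl gives an at least 1.2-fold lower number from compound 1 to compound 4 (0.10 log units; that floor lies within the scatter). The steps among compound 1, compound 2 and compound 3 cannot be read, and the new steps give only a floor: the limit of > 50000 nM in this assay, at which 3 of the 4 values shown sit.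

Still open, from the compounds shown here alone, is whether a primary amine or a longer chain ending in dimethylamino at this place would give a number further from the limit.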